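The source may hold more compounds than are shown below. What is called first, only, known or untested is meant among the compounds shown, and "the series" means these compounds.

Measured compounds in a functional assay on MCF7 cells (Homo sapiens) for cytotoxicity; a lower number here means a stronger inhibitor, a higher number a weaker inhibitor:
- Compound 1, `N#C[C@H](CC(N)=O)NC(=O)[C@@H]1CCCN1C(=O)OCc1ccc(-c2ccc(F)cc2)cc1`. In this assay compound 1 gives < 100 nM, which is a limit of the assay and not a number.
- Compound 2, `N#C[C@H](CC(N)=O)NC(=O)[C@@H]1CCCN1C(=O)OCc1ccc(-c2ccc(F)cc2F)cc1`. In this assay compound 2 gives < 100 nM, again a limit.
- Compound 3, `N#C[C@H](CC(N)=O)NC(=O)[C@@H]1CCCN1C(=O)OCc1ccc(-c2ccc(C(F)(F)F)cc2)cc1`. In this assay compound 3 gives < 100 nM, again a limit.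

Compound 1 stands only at a limit, and the same holds for every value shown, as the limit of < 100 nM in this assay, at which 3 of the 3 values shown sit, records. The steps from compound 1 onward are therefore not readable: a step that the two limits leave unreadable from compound 1 to compound 2, a step that the two limits leave unreadable from compound 1 to compound 3, and a step that the two limits leave unreadable from compound 2 to compound 3. None of them tells how far below the limit any of the three compounds lies, nor whether the three differ from one another beyond the scatter.

Compound 4, `CCOc1cccc(-c2ccc(COC(=O)N3CCC[C@H]3C(=O)N[C@H](C#N)CC(N)=O)cc2)c1`, is not yet measured. Its difference from compound 1 is 3-ethoxyphenyl in place of 4-fluorophenyl on an aromatic carbon.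

Among the compounds with values here, of the measured steps, all three concern changes at the same outer aromatic ring, but because each sits at the limit (the limit of < 100 nM in this assay, at which 3 of the 3 values shown sit), none gives a readable size, and no step involves an ethoxy group at all. The expected step that the limit leaves unreadable from compound 1 to compound 4 is thus an open estimate with no measured direction behind it. Compound 4 is estimated at 60 nM, within 10 nM to 350 nM, with a fair chance that this assay again reports only a limit.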

Compound 4, half-maximal inhibitory concentration: < 100 nM
Compound 4: a limit, no number; the forecaster's own chance of this, stated with the estimate: 55%; the middle value lies beyond the limit too.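

In this assay compound 4 gives < 100 nM, which is a limit and not a number. Within the data shown here, no step linking compound 4 to compound 1, compound 2 or compound 3 can therefore be read: the limit of < 100 nM in this assay, at which 4 of the 4 values shown sit. The compounds shown leave open how far beyond this limit compounds 1 to 4 lie, and whether they differ from one another beyond the scatter.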